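The compounds below may be only part of what the source reports. "The series", "measured", "known", "first", "only" and "open" are said of these compounds alone.

Measured so far in an assay for inhibition of RAC-alpha serine/threonine-protein kinase (Homo sapiens), read by HTRF, with a stated time of 1 h; on this read-out lower numbers stand for stronger inhibition and higher numbers for weaker inhibition:

compound 1, `CC(=O)OCC[C@@H]1C[C@@H](c2ccc(F)c(F)c2)[C@H](NC(=O)c2cc(-c3c(Cl)cnn3C)c(Cl)o2)CN1`, gives 3.4 nM
compound 2, `CNC(=O)C[C@@H]1C[C@@H](c2ccc(F)c(F)c2)[C@H](NC(=O)c2cc(-c3c(Cl)cnn3C)c(Cl)o2)CN1`, gives 1.37 nM
compound 3, `COCC[C@@H]1C[C@@H](c2ccc(Cl)c(Cl)c2)[C@H](NC(=O)c2cc(-c3c(Cl)cnn3C)c(Cl)o2)CN1`, gives 7.01 nM

Compound 3 has the highest number of the three, and so the weakest inhibition on this read-out. Its nearest neighbour is compound 1, and the furthest is compound 2; both gaps are beyond the scatter.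

Compound 4, `Cn1ncc(Cl)c1-c1cc(C(=O)N[C@@H]2CN[C@H](CCN3CCCCC3)C[C@H]2c2ccc(Cl)c(Cl)c2)oc1Cl`, has not yet been measured. It differs from compound 3 in one place: piperidin-1-yl in place of methoxy on a saturated chain carbon, two bonds along the chain from a saturated ring carbon. The chain that carries the change keeps its length; only the group at its end is exchanged.

Among the compounds with values here, only one measured step touches the same chain: a 2.5-fold lower number from compound 1 to compound 2 (0.39 log units; beyond the scatter). That step exchanged one group at the end of the chain for another and gave a modest shift, so groups at this position appear to matter, but not greatly. Within the data shown here, no measured pair shows a ring entering at this place, so the direction is uncertain.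

The step of a 1.4-fold lower number from compound 3 to compound 4 (0.15 log units; within the scatter) is therefore expected to be small, of about the size seen on this chain before, in either direction. Compound 4 is estimated at 5 nM, with a range from 1.5 nM to 17 nM.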

Compound 4, half-maximal inhibitory concentration: 5.65 nM
Beside the measured number, compound 4's estimate is 1.1-fold (0.05 log units) below it, within the range that was stated.
By their numbers in this assay, from the lowest: compound 2; then compounds 1, 4 and 3 (each within the scatter of the next, the first and the last beyond it).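

Within the data shown here, this is the first pair in which a ring enters at the end of this chain: in this assay a piperidin-1-yl group, with 6 heavy atoms and one six-membered non-aromatic ring, replaces a methoxy group of 2 heavy atoms, and the exchange gives a 1.2-fold lower number from compound 3 to compound 4 (0.09 log units; within the scatter) with no change that can be told from scatter. So, on the core of compound 3, this position accepts a much bigger end group containing a ring, whereas the earlier exchange on the same chain, a 2.5-fold lower number from compound 1 to compound 2 (0.39 log units; beyond the scatter) on the core of compound 1, was beyond the scatter, though it involved different end groups on a different core. No measurement shown here explains why the ring makes so little difference.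

Going by these compounds, whether a carboxylic acid, an open-chain amine such as dimethylamino or a longer chain at this place would also leave the number where it is remains open. On these data alone, it is also open whether piperidin-1-yl would behave the same way on the core of compound 1, which carries fluorine where compound 3 carries chlorine.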